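This account rests on a few compounds, and the source may have more. Where it says the series, first, only, none or still open, it means among the compounds named here.

Compound 3 `CNC[C@]1(O)Cc2ccccc2[C@@H]1Oc1ccccc1-c1cccc2ccccc12` gives 10000 nM in an in vitro assay on HEK293 cells for inhibition of sodium-dependent dopamine transporter (Homo sapiens) (on this read-out higher numbers stand for weaker inhibition and lower numbers for stronger inhibition), which puts it level with compound 1 `CNC[C@]1(O)Cc2ccccc2[C@@H]1Oc1ccccc1Cl` at 10000 nM, the two together being the highest numbers among the three measured; the smaller change is seen in compound 2 `CNC[C@]1(O)Cc2ccccc2[C@@H]1Oc1ccccc1F`, which gives 4000 nM. Compound 4 `CNC[C@]1(O)Cc2ccccc2[C@@H]1Oc1ccccc1SC` differs from compound 3 in one place: methylsulfanyl in place of naphthalen-1-yl on an aromatic carbon. Going by the values given here, no measured step introduces methylsulfanyl, so the guide is how far the naphthalen-1-yl matters at all: no change at the digits printed from compound 1 to compound 3 (within the scatter), and a 2.5-fold higher number from compound 2 to compound 3 (0.40 log units; beyond the scatter). Swapping the naphthalen-1-yl for a small group thus moved this assay by nothing or by a modest amount only, so compound 4 is expected at about 6000 nM, within 2500 nM to 15000 nM, which means a 1.7-fold lower number from compound 3 to compound 4 (0.22 log units; within the scatter) is expected.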

Compound 4, half-maximal inhibitory concentration: > 10000 nM
Compound 4: no number, only a limit; the forecaster's own chance of this, stated with the estimate: 30%; at least 1.6-fold (0.22 log units) between middle value and limit.
By their numbers in this assay, from the lowest: compound 2; then compounds 1 and 3 (each within the scatter of the next).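

Compound 4 gives no number here, only a limit of the assay: the limit of > 10000 nM in this assay, at which 1 of the 4 values shown sits. Even so, the change from fluoro to methylsulfanyl at this position gives an at least 2.5-fold higher number from compound 2 to compound 4 (0.39 log units; beyond the scatter), so this small sulfur group does not keep the lower number seen with fluoro. The other two steps show a number no lower from compound 1 to compound 4 (the limit leaves the size open) and a number no lower from compound 3 to compound 4 (the limit leaves the size open); their sizes cannot be read.

Going by these compounds, how far compound 4 lies beyond the limit stays open. So does whether a methoxy, a hydroxyl or an amine at this position would reverse an at least 2.5-fold higher number from compound 2 to compound 4 (0.39 log units; beyond the scatter).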